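This account rests on a few compounds, and the source may have more. Where it says the series, first, only, none or still open, it means among the compounds named here.

Measured compounds:
- compound 1, `CC1(C)CC(=O)C2=C(C1)OC(=O)C(NC(=O)c1ccccc1)C2c1ccc([N+](=O)[O-])cc1`, in a functional assay on SW 1116 cells (Homo sapiens) for cytotoxicity, read by MTT assay, with a stated time of 24 h, tested at 1 ug/mL (a higher number here means a weaker effect of the compound at the concentration tested, a lower number a stronger effect), gives 73.4%
- compound 2, `CC1(C)CC(=O)C2=C(C1)OC(=O)C(NC(=O)c1ccccc1)C2c1cccs1`, in this assay gives 104%
- compound 3, `O=C1CCCC2=C1C(c1cccs1)C(NC(=O)c1ccccc1)C(=O)O2`, in this assay gives 81.7%

Compound 2 has the highest number of the three: compound 3 lies below it, and compound 1 lower still, both beyond the scatter. The unmeasured compound 4, `CC1(C)CC(=O)C2=C(C1)OC(=O)C(NC(=O)c1ccccc1)C2c1ccco1`, differs from compound 2 by furan-2-yl in place of thiophen-2-yl on a saturated ring carbon. Within the data shown here, the only step along the same saturated ring carbon is a number 30.6 percentage points higher from compound 1 to compound 2 (beyond the scatter), a large rise, but that swapped an entirely different group; no measured pair exchanges one five-membered ring for another. The expectation is therefore a small step, a number 6 percentage points lower from compound 2 to compound 4 (within the scatter), not beyond the scatter. Compound 4 is estimated at 98%, ranging from 80% to 112%.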

Compound 4, a percentage reported as activity, at one concentration (the size of the read-out at that concentration, not a potency): 67.7%
Compound 4: middle estimate off by 30.3 percentage points, on the high side, and the stated range ends above it.
By their numbers in this assay, from the lowest: compounds 4, 1 and 3 (each within the scatter of the next, the first and the last beyond it); then compound 2.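

On this saturated ring carbon in this assay, exchanging one five-membered aromatic ring for another is not a small change: a number 36.3 percentage points lower from compound 2 to compound 4 (beyond the scatter), though only the ring's sulfur gives way to oxygen. The much larger-looking exchange gives a step within the scatter, a number 5.7 percentage points lower from compound 1 to compound 4 (within the scatter), so the size of a group's name says little here. Nothing at hand explains why these two rings part so far.

As far as these compounds go, whether a pyrrol-2-yl or a plain phenyl group at this carbon would fall nearer compound 2 or compound 4 stays open.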